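Swapping the aryl group on two related urotensin ligand cores

The compounds below may be only part of what the source reports. "The series", "measured", "known", "first", "only" and "open" are said of these compounds alone.

Compound 1 `Cc1ccccc1NC(=O)OC(CCN(C)C)c1ccc(Cl)cc1` and compound 3 `Cc1ccccc1NC(=O)NC(CCN(C)C)c1ccc(Cl)cc1` carry the same 2-methylphenyl on an amide-type nitrogen but rest on different cores; the difference between the two cores is not broken down here. In an assay on NIH3T3 cells with Urotensin-2 receptor (Homo sapiens) as the target (on this read-out lower numbers stand for an effect already at smaller amounts and higher numbers for an effect only at larger amounts of compound), compound 1 gives 3890 nM, and compound 3 gives 2290 nM, two numbers that lie within the scatter of each other. Compound 2 `COc1ccc(NC(=O)OC(CCN(C)C)c2ccc(Cl)cc2)cc1` differs from compound 1 by the change (4-methoxyphenyl in place of 2-methylphenyl on an amide-type nitrogen), and in this assay compound 2 gives 1660 nM, which makes the step of a 2.3-fold lower number from compound 1 to compound 2 (0.37 log units; beyond the scatter). Compound 4 `COc1ccc(NC(=O)NC(CCN(C)C)c2ccc(Cl)cc2)cc1`, not yet measured, differs from compound 3 by the same change (4-methoxyphenyl in place of 2-methylphenyl on an amide-type nitrogen), made at the same place. Because the measured step of a 2.3-fold lower number from compound 1 to compound 2 (0.37 log units; beyond the scatter) was modest but beyond the scatter, a step of roughly the same size is expected for compound 4, namely a 2.2-fold lower number from compound 3 to compound 4 (0.34 log units; beyond the scatter). This rests on one measured example only, so the expectation is held loosely. Compound 4 is therefore estimated at 1050 nM in this assay, within a range from 450 nM to 2500 nM.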

Compound 4, half-maximal effective concentration: 2000 nM
The estimate for compound 4 lay 1.9-fold (0.28 log units) below the measured number; the range from low to high includes it.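

On the second core, the change gives a 1.1-fold lower number from compound 3 to compound 4 (0.06 log units; within the scatter) in this assay, a step too small to tell the two compounds apart. Set beside the step on the first core, this one cannot be called different, since the gap between them is no larger than repeated measurements could produce: the same change on two cores in this assay, a 2.3-fold lower number (0.37 log units; beyond the scatter) from compound 1 to compound 2 and a 1.1-fold lower number (0.06 log units; within the scatter) from compound 3 to compound 4, 2.0-fold (0.31 log units) apart, within the scatter of two such steps The change may therefore act to a similar degree on both cores, but these two pairs do not establish that it does, and they do not show that the cores respond differently either; with one small step on each core, the carry-over remains neither confirmed nor refuted.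

The compounds shown leave open whether a plain phenyl or a cyclohexyl on the amide-type nitrogen would give steps large enough to compare clearly across the two cores. They also leave open whether the same comparison would hold with a primary amine at the end of the chain in place of the dimethylamino group.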